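Aryl exchange from compound 3 to compound 4

The compounds below may be only part of what the source reports. "The series", "measured", "known", "first", "only" and "open" are said of these compounds alone.

In a functional assay on NCI-H460 cells (Homo sapiens) for inhibition, read by MTT assay, with a stated time of 72 h (a lower number here means a stronger inhibitor, a higher number a weaker inhibitor), compound 1 `COc1cc(NC(C)CCCNC(=O)Nc2cccc(Cl)c2)c2ncccc2c1` gives 37000 nM and compound 2 `COc1cc(NC(C)CCCNC(=O)Nc2ccc(Br)cc2)c2ncccc2c1` gives 30000 nM. Compound 3 `COc1cc(NC(C)CCCNC(=O)NNC(=O)Nc2ccc(C(F)(F)F)cc2)c2ncccc2c1` gives 12000 nM, the lowest of the three numbers, and both other values stand above it by more than the scatter. Compound 4 `COc1cc(NC(C)CCCNC(=O)NNC(=O)Nc2cccc(F)c2)c2ncccc2c1` is the next entry, and its change from compound 3 is 3-fluorophenyl in place of 4-(trifluoromethyl)phenyl on an amide-type nitrogen. In words, 3-fluorophenyl takes the place of 4-(trifluoromethyl)phenyl on an amide-type nitrogen whose other neighbour is a carbonyl carbon.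

Within the data shown here, only one measured step bears on this exchange: a 1.2-fold lower number from compound 1 to compound 2 (0.09 log units; within the scatter). That step, 4-bromophenyl in place of 3-chlorophenyl, stays within the scatter. It sits on a different side chain, however, so it is only a loose guide, and no aryl exchange has been measured on the side chain of compound 3. No step beyond the scatter is therefore expected in this assay. The estimated change is a 1.3-fold higher number from compound 3 to compound 4 (0.10 log units; within the scatter). For compound 4 the expected value is 15000 nM, with an estimated range of 6000 nM to 38000 nM.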

Compound 4, half-maximal inhibitory concentration: 50000 nM
Compound 4: the middle estimate sits 3.3-fold (0.52 log units) below what was measured; the whole stated range lies below it.
By their numbers in this assay, from the lowest: compound 3; then compounds 2, 1 and 4 (each within the scatter of the next).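

In this assay, among these compounds, the aryl group on the amide-type nitrogen matters on the longer side chain: 3-fluorophenyl in place of 4-(trifluoromethyl)phenyl gives a 4.2-fold higher number from compound 3 to compound 4 (0.62 log units; beyond the scatter), whereas the only earlier aryl exchange, on the shorter side chain, stayed within the scatter. The added carbamoylamino stretch therefore does not carry the value of compound 3 by itself, since ((3-fluorophenyl)carbamoyl)amino in place of 4-bromophenyl gives a 1.7-fold higher number from compound 2 to compound 4 (0.22 log units; within the scatter) and in place of 3-chlorophenyl gives a 1.4-fold higher number from compound 1 to compound 4 (0.13 log units; within the scatter). No measurement at hand accounts for the aryl step.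

The aryl step changes both the substituent and where it sits on the phenyl ring, and the compounds shown do not separate the two. Also open, from the compounds shown here alone, is whether a phenyl ring carrying a nitrile or a carboxylic acid in place of trifluoromethyl would hold the value of compound 3.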